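From isopentyl to 2-phenylethenyl on a shared core

The source may hold more compounds than are shown below. What is called first, only, known or untested is meant among the compounds shown, and "the series" means these compounds.

Compound 1 (`CC(C)CCCN(C)Cc1ccc(C2=CCCN(C)C2)cc1`): "not determined" (no result reported) 
Compound 2 (`CN1CCC=C(c2ccc(CN(C)Cc3ccc([N+](=O)[O-])cc3)cc2)C1`): 2290 nM 

These entries come from a functional assay on HL-60 cells (Homo sapiens) for inhibition (on this read-out lower numbers stand for stronger inhibition and higher numbers for weaker inhibition), where only compound 2 has a measured number. Compound 1 has no single number on this read-out and therefore offers no measured starting point. The account follows the change from compound 1 to compound 3 (`CN1CCC=C(c2ccc(CN(C)C/C=C/c3ccccc3)cc2)C1`) as counted here: 2-phenylethenyl in place of isopentyl on a saturated chain carbon bound to an amine nitrogen. In words, 2-phenylethenyl stands in place of isopentyl on a saturated chain carbon bound to an amine nitrogen.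

Among the measured compounds shown here, the data hold no measured step for this change. With no number for compound 1, the expectation for this assay is no step beyond the scatter and no particular direction. For the measured compounds named here, the one available reference is compound 2 at 2290 nM and this single value sets the expected neighbourhood, though it says nothing about the effect of the change itself. For compound 3 the estimated value is 2500 nM with an expected range from 700 nM to 9000 nM in the measurement still to come.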

Compound 3, half-maximal inhibitory concentration: 680 nM
Beside the measured number, compound 3's estimate is 3.7-fold (0.57 log units) above it, outside the stated range (below it).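

In this assay, among the compounds shown here, compound 3 gives 680 nM while compound 1 stands at "not determined" (no result reported) and so no step from compound 1 to compound 3 can be read. Nothing at hand bears on the cause of this result. The compounds shown leave open what 2-phenylethenyl in place of isopentyl does to inhibition on this read-out.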